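Ester for methylpiperazine at the assay limit

The compounds below may be only part of what the source reports. "The series", "measured", "known", "first", "only" and "open" are said of these compounds alone.

Compound 3 (`COc1ccc(-c2nc3ccccc3s2)cc1NC(=O)c1cc([N+](=O)[O-])c(N2CCN(C)CC2)cc1Cl`) gives > 25000 nM in an ADME assay on Raji cells (Homo sapiens) for cytotoxicity, with a stated time of 72 h (a lower number here means that less compound is needed, a higher number that more compound is needed for the effect), as a limit of the assay and not a number. Compound 2 (`COc1ccc(-c2nc3ccccc3s2)cc1NC(=O)c1cc([N+](=O)[O-])c(N2CCC(C(=O)O)CC2)cc1Cl`) gives > 25000 nM as a limit too. For the measured compounds named here, the series so far offers only the limit of > 25000 nM in this assay, at which 3 of the 3 values shown sit, as its evidence, so compound 3 has no numeric place within it.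

The change to compound 4 (`COC(=O)C1CCN(c2cc(Cl)c(C(=O)Nc3cc(-c4nc5ccccc5s4)ccc3OC)cc2[N+](=O)[O-])CC1`) puts 4-(methoxycarbonyl)piperidin-1-yl in place of 4-methylpiperazin-1-yl on an aromatic carbon, ortho to a nitro group, with 4-(methoxycarbonyl)piperidin-1-yl in place of 4-methylpiperazin-1-yl on an aromatic carbon as the counted difference. Going by the values given here, the one measured step at this place is a step that the two limits leave unreadable from compound 2 to compound 3 and it has no readable size to carry over. Compound 1 (`COC(=O)C1CCN(c2cc(Cl)c(C(=O)Nc3cc(-c4nc5ccccc5s4)ccc3C)cc2[N+](=O)[O-])CC1`) also carries 4-(methoxycarbonyl)piperidin-1-yl and gives > 25000 nM as a limit. No step beyond the scatter is therefore expected, and the estimated step is a step that the limit leaves unreadable from compound 3 to compound 4 in this assay with no direction to be read from it. A further limit is the likeliest report. For compound 4 the estimated value is 30000 nM with 20000 nM to 50000 nM as the expected range.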

Compound 4, half-maximal effective concentration in the Raji assay: > 25000 nM
Compound 4: no number, only a limit; the forecaster's own chance of this, stated with the estimate: 90%; the middle value does not contradict the limit.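

In the Raji assay compound 4 gives > 25000 nM, a limit of the assay and not a number. The steps from compound 1, compound 2 and compound 3 to compound 4 in the Raji assay cannot be read, since each of these compounds gives only such a limit: the limit of > 25000 nM in the Raji assay, at which 4 of the 4 values shown sit.

In a physicochemical assay for solubility, read by spectrophotometry, in phosphate buffer, measured as kinetic solubility, with a stated time of 18 h, at pH 7.4 (on this read-out higher numbers stand for higher solubility and lower numbers for lower solubility), compound 3 gives 500 nM and compound 4 gives 170 nM, which is a 2.9-fold lower number from compound 3 to compound 4 (0.47 log units; beyond the scatter).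

The compounds shown leave open which change, if any, would bring a numeric value in the Raji assay.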